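The compounds below may be only part of what the source reports. "The series", "measured", "known", "first", "only" and "open" are said of these compounds alone.

Of the compounds shown here, three that share one core have been measured in a functional assay on A549 cells (Homo sapiens) for antiproliferative activity, read by sulforhodamine B assay, with a stated time of 3 days; a lower number here means a stronger inhibitor of growth, a higher number a weaker inhibitor of growth. Compound 1 `O=C(c1cccc(Nc2ncc(F)c(Nc3ccc(F)cc3)n2)c1)N1CCCCC1` gives 13200 nM, the highest of the three numbers. Compound 2 `O=C(NCCO)c1cccc(Nc2ncc(F)c(Nc3ccc(F)cc3)n2)c1` gives 11900 nM, and compound 3 `Cn1ccnc1NC(=O)c1cccc(Nc2ncc(F)c(Nc3ccc(F)cc3)n2)c1` gives 10100 nM. These three differ only in the group joined to the carbonyl carbon, and none of the steps between them reaches beyond the scatter: a 1.1-fold lower number from compound 1 to compound 2 (0.05 log units; within the scatter), a 1.3-fold lower number from compound 1 to compound 3 (0.12 log units; within the scatter) and a 1.2-fold lower number from compound 2 to compound 3 (0.07 log units; within the scatter). Compound 4 `O=C(Nc1cccc(Nc2ncc(F)c(Nc3ccc(F)cc3)n2)c1)c1ccccc1` has not yet been measured. It departs from compound 1 by benzamido in place of (piperidin-1-yl)carbonyl on an aromatic carbon, a change made on an aromatic carbon of a six-membered aromatic ring of carbon only, meta to a large group. The measured steps all alter what hangs on the carbonyl carbon rather than turning the amide around, so they bear only loosely on this change, yet each of them stayed within the scatter. No step beyond the scatter is therefore expected in this assay. The estimate for compound 4 is 12000 nM, between 4000 nM and 40000 nM. That estimate would mean an expected step of a 1.1-fold lower number from compound 1 to compound 4 (0.04 log units; within the scatter).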

Compound 4, concentration for 50% growth inhibition: 37800 nM
Compound 4: middle estimate off by 3.2-fold (0.50 log units), on the low side; the range from low to high includes it.
By their numbers in this assay, from the lowest: compounds 3, 2 and 1 (each within the scatter of the next); then compound 4.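

Going by these compounds alone, replacing (piperidin-1-yl)carbonyl with benzamido on this aromatic carbon produces the first step beyond the scatter in this assay (a 2.9-fold higher number from compound 1 to compound 4 (0.46 log units; beyond the scatter)), and the gaps from the other two amides are of similar modest size (a 3.2-fold higher number from compound 2 to compound 4 (0.50 log units; beyond the scatter); a 3.7-fold higher number from compound 3 to compound 4 (0.57 log units; beyond the scatter)). So this position, where changing what hangs on the carbonyl carbon had left the numbers within the scatter, does respond when the amide is turned around and a benzene ring is attached to its carbonyl. Compound 2 and compound 3 also carry an amide hydrogen, so that hydrogen alone does not set compound 4 apart, and no measurement here explains the higher number.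

Turning the amide around and adding the ring remain tied together in compound 4. Acetamido, which keeps the turned amide without the ring, and phenylcarbamoyl, which keeps the ring with the amide facing the original way, could separate the two.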